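Aryl exchange on the sulfur of compound 2

This account rests on a few compounds, and the source may have more. Where it says the series, first, only, none or still open, it means among the compounds named here.

Compound 2 `Cc1cc(C)cc(SCc2ccc(/C=C/C(=O)Nc3ccccc3N)cc2)c1` gives 8.61% in a functional assay on SMMC-7721 cells (Homo sapiens) for inhibition, read by CCK-8 assay, with a stated time of 72 h, tested at 2 uM (a higher number here means more inhibition of growth at the concentration tested, a lower number less inhibition of growth), and stands lowest of the three numbers. Compound 1 `Nc1ccccc1NC(=O)c1ccc(CSc2ccc(Br)cc2)cc1` gives 10%, within the scatter of compound 2. Compound 3 `Cc1cc(C)cc(SCc2ccc(C(=O)Nc3ccccc3N)cc2)c1` gives 29.1%, beyond the scatter. Going by the values given here, the single measured step, a number 19.1 percentage points higher from compound 1 to compound 3 (beyond the scatter), also exchanges the aryl on the sulfur, but on a core that lacks the alkene of compound 2. Compound 4 `CCc1ccc(SCc2ccc(/C=C/C(=O)Nc3ccccc3N)cc2)cc1` differs from compound 2 by 4-ethylphenyl in place of 3,5-dimethylphenyl on a sulfur. Among the compounds with values here, no measured step exchanges one alkyl-substituted aryl for another, so the bearing of a number 19.1 percentage points higher from compound 1 to compound 3 (beyond the scatter) is indirect; it shows only that an aryl exchange at this sulfur can move the number modestly. For compound 4 a step of a number 2.4 percentage points higher from compound 2 to compound 4 (within the scatter) is expected, within the scatter. Compound 4 is estimated at 11%, between 2% and 24%.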

Compound 4, percent growth inhibition at one concentration: 13.2%
The estimate for compound 4 lay 2.2 percentage points below the measured number, within the range that was stated.
By their numbers in this assay, from the lowest: compounds 2, 1 and 4 (each within the scatter of the next); then compound 3.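

In this assay, the exchange of one alkyl-substituted aryl for another on the sulfur can now be read directly, on the core carrying the alkene: a number 4.6 percentage points higher from compound 2 to compound 4 (within the scatter) is the step. On this core, 3,5-dimethylphenyl and 4-ethylphenyl, each of 8 carbon atoms, are not told apart by this read-out. No measurement of any property bears on this result.

Going by these compounds, whether an amine or a carboxylic acid on this aryl would move the number beyond the scatter stays open. So does the effect of a longer chain in place of the ethyl group.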